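Permeability notes: trimming the hydroxypiperidine amide

The source may hold more compounds than are shown below. What is called first, only, known or untested is meant among the compounds shown, and "the series" means these compounds.

Measured in an ADME assay on Caco-2 cells (Homo sapiens) for permeability, read by LC-MS, in the apical to basolateral direction, with a stated time of 2 h; a higher number here means that the compound crosses the layer faster, a lower number that the compound crosses the layer more slowly:
compound 1 `CCCN(CC1CCOC1)C(=O)c1cc(OC)c2oc(NCc3cccc(Cl)c3)nc2c1`: 246 nm/s
compound 2 `COc1cc(C(=O)N2CCC(C)(C)C2)cc2nc(NCc3cccc(Cl)c3)oc12`: "not determined" (no result reported)
compound 3 `COc1cc(C(=O)N2CC[C@@H](O)C(C)(C)C2)cc2nc(NCc3cccc(Cl)c3)oc12`: "not determined" (no result reported)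

As far as these compounds go, compound 3 has no number in this assay, and neither does compound 2, so the place of compound 3 relative to compound 1 is unknown. The next compound is compound 4 `COc1cc(C(=O)N2CCC(O)C(C)C2)cc2nc(NCc3cccc(Cl)c3)oc12`, which carries 4-hydroxy-3-methylpiperidin-1-yl in place of the 4-hydroxy-3,3-dimethylpiperidin-1-yl of compound 3 on a carbonyl carbon: 4-hydroxy-3-methylpiperidin-1-yl in place of 4-hydroxy-3,3-dimethylpiperidin-1-yl on a carbonyl carbon. Within the data shown here, the series offers no measured step from which to size this change. In this assay, no step beyond the usual scatter is expected from it, and no direction can be assigned. Among the measured compounds shown here, the only numerical anchor is compound 1 at 246 nm/s, so the expectation for the new amide rests on that single value and stays wide. For compound 4 the estimated value is 200 nm/s, with an expected range from 80 nm/s to 450 nm/s.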

Compound 4, apparent permeability: 84 nm/s
For compound 4 the middle estimate is 2.4-fold (0.38 log units) above the measured one, and the stated range covers the measured number.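

In this assay the group on the carbonyl carbon now has its first readable step, with a 2.9-fold lower number from compound 1 to compound 4 (0.47 log units; beyond the scatter) as 4-hydroxy-3-methylpiperidin-1-yl replaces ((oxolan-3-yl)methyl)(propyl)amino. The number therefore moves beyond the scatter with this one change on the shared core, which compound 1 alone could not show. Steps involving compound 2 or compound 3 cannot be read, so the change from 4-hydroxy-3,3-dimethylpiperidin-1-yl to 4-hydroxy-3-methylpiperidin-1-yl remains unsized, and nothing available explains the lower number.

A single step cannot separate the contributions of the hydroxy group, the ring and the propyl chain. Still open, as far as these compounds go, is how an amine or a carboxylic acid in place of the hydroxy group of compound 4, or a longer chain in place of the propyl group of compound 1, would read.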